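Replacing the amino side chain of compound 2

A few compounds are considered here, and "the series" means these few. Any claim that something is new, unique, unknown or untested is made for them only; others in the source may bear on it.

Measured in a functional assay on Caco-2 cells (Homo sapiens) for antiproliferative activity, read by MTT assay, with a stated time of 48 h; a lower number here means a stronger inhibitor, a higher number a weaker inhibitor:
- compound 1 `CCn1c(C(=O)NCCCN(C)C)ccc1C(CC)(CC)c1ccc(OCCC(O)(CC)CC)c(C)c1`: 490 nM
- compound 2 `CCn1c(C(=O)NCCN)ccc1C(CC)(CC)c1ccc(OCCC(O)(CC)CC)c(C)c1`: 1740 nM
- compound 3 `C=CCN(C)C(=O)c1ccc(C(CC)(CC)c2ccc(OCCC(O)(CC)CC)c(C)c2)n1CC`: > 50000 nM (a limit of the assay, not a number)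

Of the two exact values, compound 2 holds the higher one, with a 3.6-fold higher number from compound 1 to compound 2 (0.55 log units; beyond the scatter).

Compound 4 `C#CCCOC(=O)c1ccc(C(CC)(CC)c2ccc(OCCC(O)(CC)CC)c(C)c2)n1CC` differs from compound 2 in one place: (but-3-yn-1-yl)oxy in place of (2-aminoethyl)amino on a carbonyl carbon. In words, (but-3-yn-1-yl)oxy stands in place of (2-aminoethyl)amino on a carbonyl carbon.

The closest measured changes replace the same side chain on the carbonyl carbon: an at least 28-fold higher number from compound 2 to compound 3 (1.45 log units; beyond the scatter), and an at least 100-fold higher number from compound 1 to compound 3 (2.00 log units; beyond the scatter). Both are large. Compounds 1 and 2 keep an amino group on the chain, whereas compounds 3 and 4 have none. However, no measured compound carries the (but-3-yn-1-yl)oxy group, so these steps are only a guide. A large step to a higher number is therefore expected in this assay, and a limit is possible.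

The expected step is an 11-fold higher number from compound 2 to compound 4 (1.06 log units; beyond the scatter).

For compound 4 the estimate is 20000 nM, with an expected range of 4000 nM to 50000 nM.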

Compound 4, half-maximal inhibitory concentration: > 50000 nM
Compound 4: only a limit was reported; the forecaster's own chance of this, stated with the estimate: 40%; middle value at least 2.5-fold (0.39 log units) from the limit.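

In this assay, the (but-3-yn-1-yl)oxy group on the carbonyl carbon gives a second compound with no amino group on the chain and no exact value, with an at least 28-fold higher number from compound 2 to compound 4 (1.45 log units; beyond the scatter) and an at least 100-fold higher number from compound 1 to compound 4 (2.00 log units; beyond the scatter). Compound 4 gives > 50000 nM, a limit of the assay and not a number: the limit of > 50000 nM in this assay, at which 2 of the 4 values shown sit. The loss is therefore not confined to the allyl(methyl)amino group: in these four compounds, only those with an amino group on the chain give exact values, and none goes against this, although the step between compound 3 and compound 4 cannot be read.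

From the compounds shown here alone, it remains open whether the amino group or the amide hydrogen matters more. An ester carrying a dimethylamino chain and an amide with a hydroxyethyl chain would separate the two.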